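Working notes on chain lengthening near the double-bonded nitrogen

The source may report more compounds than this note shows. Statements on the series, on what has been measured and on what is new or still open speak of the compounds shown alone.

Compound 1 `C/N=C(\NC#N)NCCSCn1nc(C)ccc1=O` and compound 2 `CC/N=C(\NC#N)NCCSCn1nc(C)ccc1=O` share one core; compound 3 `CC/N=C(\NC#N)NCCSCCn1nc(-c2ccccc2)ccc1=O` carries another, and the difference between the two cores is not broken down here. In a functional assay on the whole organism (stomach) for inhibition, with Rattus norvegicus as the target, with a stated time of 4 h (a lower number here means that less compound is needed, a higher number that more compound is needed for the effect), compound 1 gives > 100 mg/kg, which is a limit of the assay. In this assay compound 2 gives > 100 mg/kg, again only a limit. The change from compound 1 to compound 2 is methyl in place of hydrogen on a saturated chain carbon bound to a double-bonded nitrogen, and the step that the two limits leave unreadable from compound 1 to compound 2 cannot be read because the limit of > 100 mg/kg in this assay, at which 2 of the 3 values shown sit, holds both compounds. Going by the values given here, compound 3 stands elsewhere: in this assay compound 3 gives < 100 mg/kg, a limit, the one value sitting at the limit of < 100 mg/kg in this assay, at which 1 of the 3 values shown sits. Compound 4 `CCC/N=C(\NC#N)NCCSCCn1nc(-c2ccccc2)ccc1=O` is not yet measured; it differs from compound 3 by methyl in place of hydrogen on a saturated chain carbon, two bonds along the chain from a double-bonded nitrogen. This is the same kind of change as from compound 1 to compound 2, but not the same: there the carbon is bound to a double-bonded nitrogen, here it sits two bonds along the chain from a double-bonded nitrogen. No readable measured step exists for this kind of change. The expected step is a step that the limit leaves unreadable from compound 3 to compound 4 and is taken as small. This rests on compound 3, whose < 100 mg/kg is a limit of the assay. Compound 4 is therefore expected at 30 mg/kg in this assay, with a range from 5 mg/kg to 100 mg/kg.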

Compound 4, dose for half-maximal effect: > 100 mg/kg
Compound 4: only a limit was reported; the forecaster's own chance of this, stated with the estimate: 40%; middle value at least 3.3-fold (0.52 log units) from the limit.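

In this assay the change of methyl in place of hydrogen on a saturated chain carbon, two bonds along the chain from a double-bonded nitrogen, gives a number no lower from compound 3 to compound 4 (the limit leaves the size open); this shows the direction of the step in the core of compound 3, while its size cannot be read, as both ends are limits of the assay. Going by these compounds alone, the related step in the core of compound 1 cannot be read either, so the two cores offer no pair of sizes to set side by side, and nothing can be said on how far a step in one core carries over to the other. The two changes also differ in place, one on a carbon bound to a double-bonded nitrogen and the other two bonds along the chain from it, so even readable steps would not be strictly the same change.

Within the data shown here, no compound here has a number in this assay, only limits. As far as these compounds go, how a butyl chain or an amine in place of the propyl group would read in the core of compound 3 stays open.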